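Swapping the basic ring end of a guanidine side chain

The compounds below may be only part of what the source reports. "The series", "measured", "known", "first", "only" and "open" are said of these compounds alone.

Measured compounds:
compound 1, `COc1ccc(Br)cc1CCc1c(F)cccc1C(=O)/N=C(\N)NCC1CCNCC1`, 31 nM
compound 2, `COc1ccc(Br)cc1CCc1c(F)cccc1C(=O)/N=C(\N)NCCCN1CCCCC1`, 330 nM
compound 3, `CCN(CC)CCCC(C)/N=C(/N)NC(=O)c1cccc(F)c1CCc1cccc2ccccc12`, 1500 nM

All three were tested in a functional assay for antagonist activity at Melanocortin receptor 4 (Homo sapiens), read by cAMP accumulation; on this read-out higher numbers stand for weaker inhibition and lower numbers for stronger inhibition. Compound 2 stands second highest of the three numbers. Its nearest neighbour is compound 3, whose value of 1500 nM is the higher of the two. The furthest is compound 1, reached by an 11-fold higher number from compound 1 to compound 2 (1.03 log units; beyond the scatter), a large step in which the whole amine end of the side chain was exchanged.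

The unmeasured compound 4, `COc1ccc(Br)cc1CCc1c(F)cccc1C(=O)/N=C(\N)NCCCN1CCN(C)CC1`, keeps the shared core and the chain of compound 2 and changes only the terminal ring: 4-methylpiperazin-1-yl in place of piperidin-1-yl on a saturated chain carbon, three bonds along the chain from an amine nitrogen.

Among the compounds with values here, only one measured step touches this part of the molecule, the step from compound 1 to compound 2, and it was large. Within the data shown here, it does not, however, exchange one ring amine for another; no measured pair does, so no direct precedent exists. The expectation is therefore a small movement, likely not beyond the scatter, with a slight lean toward a higher number because the basic end of the chain did move the value in an 11-fold higher number from compound 1 to compound 2 (1.03 log units; beyond the scatter). Compound 4 is expected to give 450 nM, in a range from 150 nM to 1400 nM. The expected step is a 1.4-fold higher number from compound 2 to compound 4 (0.13 log units; within the scatter).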

Compound 4, half-maximal inhibitory concentration: 670 nM
Compound 4: middle estimate off by 1.5-fold (0.17 log units), on the low side; the measured number falls inside the stated range.
By their numbers in this assay, from the lowest: compound 1; then compound 2; then compound 4; then compound 3.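

In this assay, within the data shown here, this is the first direct exchange of one ring amine for another at the chain end, and the terminal ring alone moves the number: a 2.0-fold higher number from compound 2 to compound 4 (0.31 log units; beyond the scatter). That modest change, 3-(piperidin-1-yl)propyl to 3-(4-methylpiperazin-1-yl)propyl, is much smaller than the change of the whole amine end, which with the new ring reads a 22-fold higher number from compound 1 to compound 4 (1.33 log units; beyond the scatter), so among the compounds sharing this core, the piperidin-4-yl end of compound 1 stays clearly ahead of both ring-ended chains. Nothing available here accounts for either step, so the numbers can only be reported as they stand.

The compounds shown leave open how other terminal rings, such as morpholin-4-yl or pyrrolidin-1-yl, would read in the same place, and whether an open diethylamine end would sit closer to piperidin-1-yl or to 4-methylpiperazin-1-yl on this core. They also leave open whether the gap between the two rings would hold on a shorter or a longer chain, or with 1-methylpiperidin-4-yl in place of the piperidin-4-yl of compound 1.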